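A few compounds are considered here, and "the series" means these few. Any claim that something is new, unique, unknown or untested is made for them only; others in the source may bear on it.

Compound 1 `O=C(CCNC(=O)c1cc(-c2ccc(F)cc2)[nH]n1)NO` and compound 2 `O=C(CCCCCCNC(=O)c1cc(-c2ccc(F)cc2)[nH]n1)NO` share one core and differ in the length of the saturated chain that ends in the hydroxycarbamoyl group. In a functional assay on A549 cells (Homo sapiens) for antiproliferative activity, read by MTT assay, with a stated time of 96 h (a lower number here means a stronger inhibitor of growth, a higher number a weaker inhibitor of growth), compound 1 gives 46900 nM and compound 2 gives 1980 nM as its result, the lower of the two numbers. Compound 3 `O=C(CCCCNC(=O)c1cc(-c2ccc(F)cc2)[nH]n1)NO` has not yet been measured. Its difference from compound 2 is hydroxycarbamoyl in place of 2-(hydroxycarbamoyl)ethyl on a saturated chain carbon, four bonds along the chain from an amide-type nitrogen and it places hydroxycarbamoyl in place of 2-(hydroxycarbamoyl)ethyl on a saturated chain carbon, four bonds along the chain from an amide-type nitrogen. Among the measured compounds shown here, one measured step bears on this change: the large one of a 24-fold lower number from compound 1 to compound 2 (1.37 log units; beyond the scatter) as the chain grows. The chain of compound 3 lies in length between those of compound 1 and compound 2, so part of that step should be given back. Two points cannot show how the number follows chain length, so the size stays uncertain. In this assay a higher number is expected, with a step smaller than the measured one. The estimate is a 4.5-fold higher number from compound 2 to compound 3 (0.66 log units; beyond the scatter) as the expected move. For compound 3 the expected value is 9000 nM with 3500 nM to 25000 nM as the estimated range.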

Compound 3, concentration for 50% growth inhibition: > 100000 nM
Compound 3 was reported as a limit (the forecaster's own chance of this, stated with the estimate: 2%); at least 11-fold (1.04 log units) between middle value and limit.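

In this assay compound 3 gives only a limit, > 100000 nM, and not a number. Exchanging 2-(hydroxycarbamoyl)ethyl for hydroxycarbamoyl at this saturated chain carbon brings an at least 50-fold higher number from compound 2 to compound 3 (1.70 log units; beyond the scatter), so removing just this part of the chain loses all of the growth inhibition that the longest chain shown had gained. Compared with the shortest chain, the change gives an at least 2.1-fold higher number from compound 1 to compound 3 (0.32 log units; beyond the scatter), so across these three compounds the number does not follow chain length in one direction: the chain of middle length, not the shortest one, gives the weakest growth inhibition.

As far as these compounds go, how far the true value of compound 3 lies past its reading stays unknown: the limit of > 100000 nM in this assay, at which 1 of the 3 values shown sits. Still open are whether a chain one carbon longer or shorter than that of compound 2, or a longer chain than any shown here, would lower the number further, and whether a carboxylic acid in place of the hydroxycarbamoyl group would keep any growth inhibition.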